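Swapping a pentafluorosulfanyl for trifluoromethyl on a second core

A few compounds are considered here, and "the series" means these few. Any claim that something is new, unique, unknown or untested is made for them only; others in the source may bear on it.

Of the compounds shown here, three have been measured so far in a functional assay on CWR22R cells (Homo sapiens) for antiproliferative activity, read by propidium iodide staining, with a stated time of 96 h; a lower number here means a stronger inhibitor, a higher number a weaker inhibitor. Compound 1, `CC(O)(CSc1ccc(S(F)(F)(F)(F)F)cc1)C(=O)Nc1ccc(S(F)(F)(F)(F)F)cc1`, gives 24400 nM. Compound 2, `CC(O)(CSc1ccc(C(F)(F)F)cc1)C(=O)Nc1ccc(S(F)(F)(F)(F)F)cc1`, gives 14800 nM. The change from compound 1 to compound 2 is a group of 4 heavy atoms (1 carbon, 3 fluorine; no ring) in place of a group of 6 heavy atoms (5 fluorine, 1 sulfur; no ring), on an aromatic carbon, and it produced a 1.6-fold lower number from compound 1 to compound 2 (0.22 log units; within the scatter). Compound 3, `CC(O)(COc1ccc(S(F)(F)(F)(F)F)cc1)C(=O)Nc1cccc(S(F)(F)(F)(F)F)c1`, gives 10200 nM; its value lies within the scatter of the value of compound 2 and is lower than the value of compound 1. How the core of compound 3 differs from the core of compound 1 is not broken down here.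

Compound 4, `CC(O)(COc1ccc(C(F)(F)F)cc1)C(=O)Nc1cccc(S(F)(F)(F)(F)F)c1`, has not yet been measured in this assay. Its difference from compound 3 is a group of 4 heavy atoms (1 carbon, 3 fluorine; no ring) in place of a group of 6 heavy atoms (5 fluorine, 1 sulfur; no ring), on an aromatic carbon. Going by the values given here, this is the same change as that from compound 1 to compound 2, with the place described in the same words, so the step already seen is the only guide available. On that basis the step from compound 3 to compound 4 is expected to be about a 1.5-fold lower number from compound 3 to compound 4 (0.16 log units; within the scatter), lying beside a 1.6-fold lower number from compound 1 to compound 2 (0.22 log units; within the scatter) and resting on the value of compound 3, 10200 nM, as the starting point. Compound 4 is therefore estimated to give 7000 nM in this assay, with the likely range running from 3500 nM to 14000 nM.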

Compound 4, half-maximal inhibitory concentration: 3600 nM
The estimate for compound 4 lay 1.9-fold (0.29 log units) above the measured number, and the stated range covers the measured number.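

On the second core, putting trifluoromethyl in place of pentafluorosulfanyl in this assay gave a 2.8-fold lower number from compound 3 to compound 4 (0.45 log units; beyond the scatter), the same direction as on the first core, where the earlier step could not be told apart from the scatter. Going by these compounds alone, the sizes of the two steps cannot be told apart either, so the change shows no measurable dependence on the core across these two cases: the same change on two cores in this assay, a 1.6-fold lower number (0.22 log units; within the scatter) from compound 1 to compound 2 and a 2.8-fold lower number (0.45 log units; beyond the scatter) from compound 3 to compound 4, 1.7-fold (0.24 log units) apart, within the scatter of two such steps This does not show that the exchange works more strongly on the second core, even though only that step clears the scatter on its own, and two cores are too few to support a rule for the whole series.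

The compounds shown leave open whether other groups at this place on the aromatic ring, such as a chlorine atom, a nitrile or a methoxy group, would follow the same trend, and whether the pentafluorosulfanyl on the anilide ring would respond to the same exchange. The core of compound 1 and the core of compound 3 differ in more than one place, and what each of those differences contributes cannot be read from these compounds.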